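This account rests on a few compounds, and the source may have more. Where it says the series, first, only, none or still open, it means among the compounds named here.

Measured compounds in a functional assay on CHO-K1 cells (Cricetulus griseus) for inhibition, read by MTT assay, with a stated time of 72 h; on this read-out higher numbers stand for weaker inhibition and lower numbers for stronger inhibition:
compound 1 `CCCNC(=C\C(=O)/C=C/c1ccc(O)c(OC)c1)/C=C/c1ccc(O)c(OC)c1` gives > 25000 nM, a limit of the assay.
compound 2 `C=CCNC(=C\C(=O)/C=C/c1ccc(O)c(OC)c1)/C=C/c1ccc(O)c(OC)c1` gives 7400 nM.
compound 3 `CCC(C)NC(=C\C(=O)/C=C/c1ccc(O)c(OC)c1)/C=C/c1ccc(O)c(OC)c1` gives > 25000 nM, a limit of the assay.

Compound 3 therefore stands at the limit of this assay, with no number of its own. Two of the three values sit at that limit (the limit of > 25000 nM in this assay, at which 2 of the 3 values shown sit). For the measured compounds named here, only compound 2 gives a number, and the one readable step into compound 3 is an at least 3.3-fold higher number from compound 2 to compound 3 (0.52 log units; beyond the scatter); the step that the two limits leave unreadable from compound 1 to compound 3 is unreadable, both values being limits.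

Compound 4 `CCCCNC(=C\C(=O)/C=C/c1ccc(O)c(OC)c1)/C=C/c1ccc(O)c(OC)c1` keeps the shared core and differs from compound 3 at the amine nitrogen only: butyl in place of sec-butyl on an amine nitrogen. Going by the values given here, no measured step sets butyl against sec-butyl. The nearest guide is compound 1, whose propyl differs from butyl in chain length alone and which also sits at the limit; compound 3, with sec-butyl, sits there too. The allyl of compound 2, the only substituent that gave a number, is absent here. Hence no step beyond the scatter is expected in this assay, and compound 4 is expected to remain at the limit, a step that the limit leaves unreadable from compound 3 to compound 4. The estimate for compound 4 is 40000 nM, with a range from 15000 nM to 150000 nM.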

Compound 4, half-maximal inhibitory concentration: 7000 nM
For compound 4 the middle estimate is 5.7-fold (0.76 log units) above the measured one; the whole stated range lies above it.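

In this assay, the atoms of the chain on the amine nitrogen are not enough to set the result, since butyl in place of sec-butyl, with the same atoms joined differently, gives an at least 3.5-fold lower number from compound 3 to compound 4 (0.55 log units; beyond the scatter). An allyl group is also not required for a readable number: lengthening propyl to butyl gives an at least 3.5-fold lower number from compound 1 to compound 4 (0.55 log units; beyond the scatter), and setting butyl against allyl gives a 1.1-fold lower number from compound 2 to compound 4 (0.02 log units; within the scatter). The values of compound 1 and compound 3 remain limits and not numbers: the limit of > 25000 nM in this assay, at which 2 of the 4 values shown sit.

The two steps out of those limits give only a lower bound on their size, so how far butyl truly stands from propyl or sec-butyl cannot be read. As far as these compounds go, whether a longer chain such as pentyl or hexyl, or a branched isobutyl group, on the amine nitrogen gives a readable number stays open.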